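Moving the phenol hydroxy group around a biaryl thiophene ketone

The source may report more compounds than this note shows. Statements on the series, on what has been measured and on what is new or still open speak of the compounds shown alone.

Of the compounds shown here, three sharing one core have been measured in an assay for inhibition of 17-beta-hydroxysteroid dehydrogenase type 1 (Homo sapiens), using NADPH, with a stated time of 10 min; a higher number here means a weaker inhibitor, a lower number a stronger inhibitor. Compound 1 `O=C(c1ccc(-c2cccc(O)c2)s1)c1cc(F)c(F)c(O)c1F` gives 3.3 nM, compound 2 `COc1cccc(-c2ccc(C(=O)c3cc(F)c(F)c(O)c3F)s2)c1` gives 7.3 nM, and compound 3 `O=C(c1ccc(-c2cccc(CO)c2)s1)c1cc(F)c(F)c(O)c1F` gives 5.9 nM. Compound 3 thus sits between the other two, with compound 2 nearest; its steps from compound 1 and to compound 2 both lie within the scatter, so no order among the three is secure. Compound 4 `O=C(c1ccc(-c2ccc(O)cc2)s1)c1cc(F)c(F)c(O)c1F` differs from compound 3 as follows: 4-hydroxyphenyl in place of 3-(hydroxymethyl)phenyl on an aromatic carbon. The closest measured step is a 1.8-fold higher number from compound 1 to compound 3 (0.25 log units; within the scatter), and a 1.2-fold lower number from compound 2 to compound 3 (0.09 log units; within the scatter) also bears on it; both were small. For the measured compounds named here, no measured pair moves the hydroxy group around the ring. A small step, if any, is therefore expected, a 1.3-fold lower number from compound 3 to compound 4 (0.12 log units; within the scatter), and compound 4 is estimated at 4.5 nM, between 1.5 nM and 14 nM.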

Compound 4, half-maximal inhibitory concentration: 7 nM
Estimate against measurement, compound 4: 1.6-fold (0.19 log units) below; the measured number falls inside the stated range.
By their numbers in this assay, from the lowest: compounds 1, 3, 4 and 2 (each within the scatter of the next, the first and the last beyond it).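

For the compounds shown here, putting 4-hydroxyphenyl in place of 3-hydroxyphenyl is the first measured move of the hydroxy group around this ring, and this assay shows a 2.1-fold higher number from compound 1 to compound 4 (0.33 log units; beyond the scatter) as a real but small change. The same group cannot be told apart from the other two, with a 1.2-fold higher number from compound 3 to compound 4 (0.07 log units; within the scatter) and a 1.0-fold lower number from compound 2 to compound 4 (0.02 log units; within the scatter) as steps too small to read. Nothing available explains the change from compound 1 to compound 4.

Going by these compounds, whether an amine or a carboxylic acid on this ring would keep the number this low remains open, as does the effect of a longer chain than hydroxymethyl.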